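A few compounds are considered here, and "the series" means these few. Any claim that something is new, unique, unknown or untested is made for them only; others in the source may bear on it.

Compounds measured in an assay on CHO cells for displacement of a labelled ligand from transient receptor potential cation channel subfamily V member 1 (Rattus norvegicus); a higher number here means a weaker inhibitor, a lower number a stronger inhibitor:
compound 1, `COc1cc(CNC(=S)NCC(COC(=O)C(C)(C)C)Cc2ccc(C(C)(C)C)cc2)c(I)cc1O`, 13.3 nM;
compound 2, `COc1cc(CNC(=S)NC(CCc2ccc(C(C)(C)C)cc2)COC(=O)C(C)(C)C)cc(Cl)c1O`, 122 nM;
compound 3, `COc1cc(CNC(=S)NC(CCc2ccc(C)c(C)c2)COC(=O)C(C)(C)C)cc(Cl)c1O`, 86 nM.

Among these three numbers compound 3 stands second highest. Its nearest neighbour is compound 2, and the step of a 1.4-fold lower number from compound 2 to compound 3 (0.15 log units; within the scatter) lies within the scatter. Compound 1 lies furthest off, with a lower number than compound 3, but compound 1 differs from compound 3 in more than one place, so no single step can be read from that pair.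

Compound 4, `COc1cc(CNC(=S)NC(CCc2ccc(C)c(C)c2)COC(=O)C(C)(C)C)c(Br)cc1O`, has not been measured in this assay. It differs from compound 3 by 2-bromo-4-hydroxy-5-methoxyphenyl in place of 3-chloro-4-hydroxy-5-methoxyphenyl on a saturated chain carbon bound to an amide-type nitrogen. Among the compounds with values here, none of the measured steps touches this part of the molecule; the only measured step changes the aryl group three bonds along the chain, and it stays within the scatter. The data therefore give no direct guide to the direction of the change from compound 3 to compound 4, and only compound 1 shows that a compound carrying a halogen in the 2-position of this ring can reach a low number. With that thin support, compound 4 is expected to give about 45 nM in this assay, within a range from 12 nM to 170 nM, which would be the step of a 1.9-fold lower number from compound 3 to compound 4 (0.28 log units; within the scatter), though an outcome within the scatter of compound 3 is also expected to be possible.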

Compound 4, inhibition constant: 109 nM
Compound 4: middle estimate off by 2.4-fold (0.38 log units), on the low side; low and high end bracket the measured number.
By their numbers in this assay, from the lowest: compound 1; then compounds 3, 4 and 2 (each within the scatter of the next).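

In this assay, replacing 3-chloro-4-hydroxy-5-methoxyphenyl with 2-bromo-4-hydroxy-5-methoxyphenyl on a saturated chain carbon bound to an amide-type nitrogen gives a 1.3-fold higher number from compound 3 to compound 4 (0.10 log units; within the scatter). Within the data shown here, this is the first measured step at this part of the molecule, and it shows that, with the 3,4-dimethylphenyl group in place, the two halogenated aryl groups cannot be told apart in this assay. The data shown offer no independent measurement that would account for this result.

The step changes both the halogen and its place on the ring, so the contribution of each remains unresolved, and 3-bromo-4-hydroxy-5-methoxyphenyl or 2-chloro-4-hydroxy-5-methoxyphenyl would be needed to separate them. From the compounds shown here alone, compound 1 differs from compound 4 in more than one place, so what sets its number apart also remains open.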